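This account rests on a few compounds, and the source may have more. Where it says the series, first, only, none or still open, it means among the compounds named here.

Measured in a functional assay on CCRF-CEM cells (Homo sapiens) for inhibition; on this read-out higher numbers stand for weaker inhibition and lower numbers for stronger inhibition:
Compound 1 `OC[C@H]1C=C(F)[C@H](n2cnc3c(O)ncnc32)O1`: > 100000 nM
Compound 2 `Nc1ncnc2c1ncn2[C@H]1O[C@@H](CO)C=C1F`: > 100000 nM

Compound 2 stands at > 100000 nM, which is a limit and not a number. The data so far hold only (the limit of > 100000 nM in this assay, at which 2 of the 2 values shown sit). Compound 3 `OC[C@H]1C=C(F)[C@@H](n2cnc3c(O)ncnc32)O1` differs from compound 2 by one change, hydroxy in place of amino on an aromatic carbon. Compound 1 also carries hydroxy, and its > 100000 nM is likewise a limit. Going by the values given here, no measured pair shows this change alone, so no shift beyond the scatter is expected in this assay, an estimated a number no higher from compound 2 to compound 3 (the limit leaves the size open). For compound 3 the expected value is 100000 nM, with an estimated range from 30000 nM to 200000 nM.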

Compound 3, half-maximal inhibitory concentration: > 100000 nM
Compound 3: no number, only a limit; the forecaster's own chance of this, stated with the estimate: 85%; the middle value sits exactly at the limit.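

No step can be read from compound 2 to compound 3 or from compound 1 to compound 3, since each comparison rests on two limits: the limit of > 100000 nM in this assay, at which 3 of the 3 values shown sit.

The compounds shown leave open whether hydroxy in place of amino, or the configuration as drawn, changes inhibition in this assay.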